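The source may hold more compounds than are shown below. What is called first, only, known or untested is meant among the compounds shown, and "the series" means these compounds.

In a functional assay on A549 cells (Homo sapiens) for antiproliferative activity, read by MTT assay, with a stated time of 72 h (on this read-out lower numbers stand for stronger inhibition and higher numbers for weaker inhibition), three compounds that share one core and differ in a single aryl group have been measured: compound 1 `COc1ccccc1-c1ccc2ncn(-c3cc(OC)c(OC)c(OC)c3)c2c1` gives 4320 nM, compound 2 `COc1ccc(-c2ccc3ncn(-c4cc(OC)c(OC)c(OC)c4)c3c2)cc1F` gives 1430 nM, and compound 3 `COc1cc(-n2cnc3ccc(-c4cccc([N+](=O)[O-])c4)cc32)cc(OC)c1OC` gives 5410 nM. Compound 3 stands level with compound 1, as a 1.3-fold higher number from compound 1 to compound 3 (0.10 log units; within the scatter) lies within the scatter. Both sit at the higher end of this small set, since a 3.8-fold higher number from compound 2 to compound 3 (0.58 log units; beyond the scatter) goes beyond the scatter, as does a 3.0-fold lower number from compound 1 to compound 2 (0.48 log units; beyond the scatter).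

Compound 4 `COc1cc(-n2cnc3ccc(-c4ccc(Cl)cc4Cl)cc32)cc(OC)c1OC` has not yet been measured. It has 2,4-dichlorophenyl in place of 3-nitrophenyl on an aromatic carbon. Going by the values given here, no measured compound carries this group, so the only guidance comes from the three exchanges at the same place, and none of them exceeds a modest size. The largest of these is a 3.8-fold higher number from compound 2 to compound 3 (0.58 log units; beyond the scatter), and neither compound 1 nor compound 2 shows a number clearly above that of compound 3. A small step towards a lower number in this assay is therefore expected, possibly no larger than the scatter. The expected change is a 1.9-fold lower number from compound 3 to compound 4 (0.27 log units; within the scatter). For compound 4 the estimated value is 2900 nM, with an expected range from 1200 nM to 7000 nM.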

Compound 4, half-maximal inhibitory concentration: > 10000 nM
Compound 4 ended at the assay's limit; the forecaster's own chance of this, stated with the estimate: 3%; middle value at least 3.4-fold (0.53 log units) from the limit.
By their numbers in this assay, from the lowest: compound 2; then compounds 1 and 3 (each within the scatter of the next). At a limit, above all of these: compound 4.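

In this assay compound 4 stands at a limit of the assay and not at a number: the limit of > 10000 nM in this assay, at which 1 of the 4 values shown sits.

Read against the two methoxy-bearing aryl groups, the change to 2,4-dichlorophenyl gives a clear rise, with an at least 6.9-fold higher number from compound 2 to compound 4 (0.84 log units; beyond the scatter) and an at least 2.3-fold higher number from compound 1 to compound 4 (0.36 log units; beyond the scatter), so this position can lose more than the earlier exchanges alone showed. Against the group it replaces, the result is less firm: the step is an at least 1.8-fold higher number from compound 3 to compound 4 (0.26 log units; that floor lies within the scatter), so the limit does not by itself set 2,4-dichlorophenyl apart from 3-nitrophenyl.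

The compounds shown leave open how far the true value of compound 4 lies beyond the limit, and whether the loss follows from the two chlorines together or from one of them alone. From the compounds shown here alone, they also do not tell whether a phenyl ring carrying a single chlorine, an amine or a carboxylic acid at this place would return towards compound 2 or stay with compound 4, and the reason for the rise remains unknown.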